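Ring fluoro position and cytotoxicity, compound 2 to compound 3

The source may hold more compounds than are shown below. What is called first, only, known or untested is meant among the compounds shown, and "the series" means these compounds.

Compound 2 `COc1cc(N(C)C(=O)c2ccccc2)cc(OC)c1OC` in a functional assay on ONS-76 cells (Homo sapiens) for cytotoxicity, read by MTT assay, with a stated time of 72 h (on this read-out lower numbers stand for stronger inhibition and higher numbers for weaker inhibition), sits at a limit of the assay, >= 125000 nM. Its fluoro partner compound 1 `COc1cc(N(C)C(=O)c2cccc(F)c2)cc(OC)c1OC` likewise returns only a limit, >= 125000 nM. For the measured compounds named here, the step that the two limits leave unreadable from compound 1 to compound 2 is therefore unreadable, and the sole evidence is the limit of >= 125000 nM in this assay, at which 2 of the 2 values shown sit. Compound 3 `COc1cc(N(C)C(=O)c2ccc(F)cc2)cc(OC)c1OC` differs from compound 2 by fluoro in place of hydrogen on an aromatic carbon. Going by the values given here, no measured step offers a readable size, so the expected step that the limit leaves unreadable from compound 2 to compound 3 is none beyond the scatter. Compound 3 is expected to return a limit again, with the estimate 150000 nM and a range of 60000 nM to 400000 nM.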

Compound 3, half-maximal inhibitory concentration: >= 125000 nM
Compound 3 was reported as a limit; the forecaster's own chance of this, stated with the estimate: 85%; the middle value is on the limit's open side.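

Compound 3 gives no readable step against compound 1 or compound 2, as all three return only a limit: the limit of >= 125000 nM in this assay, at which 3 of the 3 values shown sit.

The compounds shown leave open whether any change to the shared core gives a measurable value in this assay.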